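Replacing a bicyclic amine with piperazine in compound 3

The source may report more compounds than this note shows. Statements on the series, on what has been measured and on what is new or still open speak of the compounds shown alone.

Measured so far in an ADME assay on microsomes from liver (Homo sapiens) for metabolic stability, read by LC-MS, with a stated time of 10 min; a lower number here means that less of the compound is left, a higher number that more of the compound is left:
compound 1 `CN(C[C@H]1Cc2c(cccc2N2CCN(C3COC3)CC2)CN1)[C@H]1CCCc2cccnc21` gives 83.1%
compound 2 `CN(C[C@@H]1Cc2c(cccc2N2CCNCC2)CN1)[C@H]1CCCc2cccnc21` gives 94.2%
compound 3 `CN(C[C@H]1Cc2c(cccc2N2CCN3CCC[C@H]3C2)CN1)[C@H]1CCCc2cccnc21` gives 36.6%

Compound 3 stands lowest of the three numbers in this assay; its nearest neighbour is compound 1, and compound 2 lies furthest above it, both beyond the scatter. Going by the values given here, the only step measured so far that touches the group on the aromatic carbon of compound 3 is a number 46.5 percentage points lower from compound 1 to compound 3 (beyond the scatter), a large fall.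

Compound 4 `CN(C[C@H]1Cc2c(cccc2N2CCNCC2)CN1)[C@H]1CCCc2cccnc21` has not yet been measured. Its change from compound 3 is a group of 6 heavy atoms (4 carbon, 2 nitrogen; one six-membered non-aromatic ring with 2 hetero atoms) in place of a group of 9 heavy atoms (7 carbon, 2 nitrogen; one five-membered non-aromatic ring with 1 hetero atom, one six-membered non-aromatic ring with 2 hetero atoms), on an aromatic carbon

The step from compound 1 to compound 3 bears directly on this: it shows that the group now leaving compound 3 went with the lowest number of the set, and removing it should reverse that fall. Compound 2 carries the piperazin-1-yl group and gives 94.2%, the highest number of the three. Compound 4 is therefore expected to rise well beyond the scatter, by a number 48.4 percentage points higher from compound 3 to compound 4 (beyond the scatter), with the direction considered firm and the exact size less so. The estimate for compound 4 in this assay is 85%, with a range from 70% to 97%.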

Compound 4, percent of the compound remaining: 99.7%
Compound 4: middle estimate off by 14.7 percentage points, on the low side, outside the stated range (above it).
By their numbers in this assay, from the lowest: compound 3; then compound 1; then compounds 2 and 4 (each within the scatter of the next).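

In this assay, the piperazin-1-yl group on the aromatic carbon stands far above the bicyclic group it replaces, a number 63.1 percentage points higher from compound 3 to compound 4 (beyond the scatter), so the low number of compound 3 goes with that group and not with the rest of the molecule. The free ring nitrogen also counts for something, since the oxetan-3-yl compound, though well above compound 3, does not match it: the step is a number 16.6 percentage points higher from compound 1 to compound 4 (beyond the scatter). The configuration at the saturated ring carbon leaves no readable mark in this pair, with a number 5.5 percentage points higher from compound 2 to compound 4 (within the scatter), and this comparison isolates that single centre: the fact that compounds 2 and 4 differ only in the configuration as drawn.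

From the compounds shown here alone, what remains open is whether the fall in compound 3 follows from the added fused ring or simply from carrying a carbon substituent on that nitrogen, a question that a methyl or an acetyl on the piperazine nitrogen would help to separate. It also remains open whether the configuration stays without effect once the ring nitrogen carries oxetan-3-yl or the bicyclic group replaces the piperazine, since only the unsubstituted piperazine is shown in both forms.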